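Thiophene in place of chlorophenyl on the shared core

A few compounds are considered here, and "the series" means these few. Any claim that something is new, unique, unknown or untested is made for them only; others in the source may bear on it.

The series holds compound 1 `CCCCCCCCc1ccc(OCC(=O)Cn2nnc(-c3ccc(Cl)cc3)n2)cc1`, compound 2 `CCCCCCCCc1ccc(OCC(=O)Cn2nnc(-c3ccc(S(=O)(=O)N(C)C)cc3)n2)cc1` and compound 3 `CCCCCCCCc1ccc(OCC(=O)Cn2nnnc2-c2ccccc2Cl)cc1`. In an assay on microsomes from brain for inhibition of Fatty-acid amide hydrolase 1 (Rattus norvegicus), read by fluorescence and HPLC, with a stated time of 60 min (on this read-out lower numbers stand for stronger inhibition and higher numbers for weaker inhibition), compound 1 gives 35 nM, compound 2 gives 590 nM, and compound 3 gives 4600 nM, the highest of the three numbers; compound 2 sits nearest to it and compound 1 furthest, both gaps beyond the scatter. Going by the values given here, the only single-point step measured so far is a 17-fold higher number from compound 1 to compound 2 (1.23 log units; beyond the scatter). Compound 4 `CCCCCCCCc1ccc(OCC(=O)Cn2nnnc2-c2cccs2)cc1` follows from compound 3 by thiophen-2-yl in place of 2-chlorophenyl on an aromatic carbon. Among the compounds with values here, no measured step concerns this change: the step from compound 1 to compound 2 swaps a substituent on the aromatic ring, whereas here the whole ring is exchanged, and both compound 1 and compound 2 differ from compound 3 in how the aryl is joined to the shared core, so the large size of that step cannot be carried over. Without a comparable precedent, for compound 4 the expected step is a 1.5-fold lower number from compound 3 to compound 4 (0.19 log units; within the scatter), small and without a firm direction. Compound 4 is estimated at 3000 nM, with a range from 700 nM to 13000 nM.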

Compound 4, half-maximal inhibitory concentration: 55 nM
Compound 4: middle estimate off by 55-fold (1.74 log units), on the high side; the whole stated range lies above it.
By their numbers in this assay, from the lowest: compounds 1 and 4 (each within the scatter of the next); then compound 2; then compound 3.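

In this assay, the aromatic carbon between two ring nitrogen atoms responds strongly to an exchange of the whole ring: thiophen-2-yl in place of 2-chlorophenyl gives an 84-fold lower number from compound 3 to compound 4 (1.92 log units; beyond the scatter). Going by these compounds alone, the earlier step showed only a substituent swap on an aromatic ring of a differently joined aryl, so this is the first reading at this position. The change removes the chlorine and the six-membered ring together and brings in a five-membered ring with a hetero atom, and no available data explain the size of the step.

Plain phenyl or furan-2-yl at this carbon would help separate the part played by the chlorine from that of the ring itself. Going by these compounds, how thiophen-2-yl behaves on the core of compound 1 remains open.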